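A few compounds are considered here, and "the series" means these few. Any claim that something is new, unique, unknown or untested is made for them only; others in the source may bear on it.

Among the compounds with values here, in a functional assay on MGC-803 cells (Homo sapiens) for inhibition, read by sulforhodamine B assay (on this read-out lower numbers stand for stronger inhibition and higher numbers for weaker inhibition), compound 2 (`COc1ccc(NC2=CC(=O)c3nc4n(c3C2=O)[C@H]2OC[C@@H](O)[C@H]2OC4)cc1`) gives 1680 nM, the only number so far. Compound 1 (`O=C1C=C(N2CCC2)C(=O)c2c1nc1n2[C@H]2OC[C@@H](O)[C@H]2OC1`) stands at > 16000 nM, which is a limit. Compound 3 (`O=C1C=C(Nc2ccccc2)C(=O)c2c1nc1n2[C@H]2OC[C@@H](O)[C@H]2OC1`) has hydrogen in place of methoxy on an aromatic carbon, para to a large group (hydrogen in place of methoxy on an aromatic carbon). Within the data shown here, the one measured step, an at least 9.5-fold lower number from compound 1 to compound 2 (0.97 log units; beyond the scatter), replaced azetidin-1-yl with the whole (4-methoxyphenyl)amino group, so it bears only indirectly and does not isolate the methoxy. The expected change is a 1.2-fold higher number from compound 2 to compound 3 (0.08 log units; within the scatter), with no step beyond the scatter and no firm direction expected. The estimate for compound 3 is 2000 nM, with an expected range of 700 nM to 6000 nM.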

Compound 3, half-maximal inhibitory concentration: 1730 nM
Compound 3: the middle estimate sits 1.2-fold (0.06 log units) above what was measured, and the stated range covers the measured number.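

In this assay, hydrogen in place of methoxy on the aromatic carbon para to a large group gives a 1.0-fold higher number from compound 2 to compound 3 (0.01 log units; within the scatter), so this read-out does not separate compound 2 from compound 3 and the methoxy is not needed to hold the value. The anilino group alone, without the methoxy, accounts for an at least 9.2-fold lower number from compound 1 to compound 3 (0.96 log units; beyond the scatter). Compound 1 stands at a limit, not a number, so that step is only a bound: the limit of > 16000 nM in this assay, at which 1 of the 3 values shown sits.

As far as these compounds go, how an amine, a carboxylic acid or a chlorine atom would read on this aromatic carbon stays open. So does how a piperidin-1-yl group would read in place of the anilino group.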